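From trifluoromethoxy to methyl: a clearance estimate

The source may report more compounds than this note shows. Statements on the series, on what has been measured and on what is new or still open speak of the compounds shown alone.

In an in vitro ADME assay on microsomes from liver (Homo sapiens) for metabolic stability, using NADPH (on this read-out lower numbers stand for slow clearance and higher numbers for fast clearance), compound 1 (`CC(C)(CO)CNC(=O)c1cc2cc(C#N)ccc2n1Cc1cccc(OC(F)(F)F)c1`) gives 62 mL.min-1.g-1, compound 2 (`COc1ccc(OC(F)(F)F)cc1Cn1c(C(=O)NCC(C)(C)CO)cc2cc(C#N)ccc21`) gives 69 mL.min-1.g-1 and compound 3 (`COc1ccc(Cl)cc1Cn1c(C(=O)NCC(C)(C)CO)cc2cc(C#N)ccc21`) gives 83 mL.min-1.g-1. Compound 2 therefore lies within the scatter of both compound 1 and compound 3. Compound 4 (`COc1ccc(C)cc1Cn1c(C(=O)NCC(C)(C)CO)cc2cc(C#N)ccc21`) differs from compound 2 as follows: methyl in place of trifluoromethoxy on an aromatic carbon. This places methyl in place of trifluoromethoxy on an aromatic carbon. The closest measured change, chloro in place of trifluoromethoxy, is a 1.2-fold higher number from compound 2 to compound 3 (0.08 log units; within the scatter). Methoxy in place of hydrogen on an aromatic carbon is a 1.1-fold higher number from compound 1 to compound 2 (0.05 log units; within the scatter). Neither step exceeds the scatter, so no step beyond it is expected, and the estimated step is a 1.1-fold higher number from compound 2 to compound 4 (0.05 log units; within the scatter). The estimate for compound 4 is 78 mL.min-1.g-1, with an expected range of 50 mL.min-1.g-1 to 120 mL.min-1.g-1.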

Compound 4, intrinsic clearance in microsomes: 191 mL.min-1.g-1
The estimate for compound 4 lay 2.4-fold (0.39 log units) below the measured number; the measured number lies above the stated range.
By their numbers in this assay, from the lowest: compounds 1, 2 and 3 (each within the scatter of the next); then compound 4.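

In this assay the group at this position, para to a methoxy group, does matter: methyl in place of trifluoromethoxy gives a 2.8-fold higher number from compound 2 to compound 4 (0.44 log units; beyond the scatter) and methyl in place of chloro gives a 2.3-fold higher number from compound 3 to compound 4 (0.36 log units; beyond the scatter). Trifluoromethoxy and chloro themselves stay within the scatter of each other, so among the compounds shown only methyl stands apart. Nothing available here accounts for this rise. Going by these compounds, whether it is particular to methyl stays open. An ethyl group or a fluoro group at the same place would test this.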